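This account rests on a few compounds, and the source may have more. Where it says the series, first, only, none or still open, it means among the compounds named here.

Compound 1 `Cc1ccc(-c2ccsc2S(=O)(=O)NCCNC(=O)Nc2cc(C(F)(F)F)cc(C(F)(F)F)c2)c(Oc2ccc(O)c(O)c2)c1` has been measured in an ADME assay on HEK-293T cells (Homo sapiens) for cytotoxicity, read by CCK-8 assay, with a stated time of 48 h (a lower number here means a stronger inhibitor, a higher number a weaker inhibitor), and there compound 1 gives > 20000 nM. That value is a limit and not a number. Compound 2 `O=C(NCCNS(=O)(=O)c1ccc(-c2ccccc2Oc2ccc([N+](=O)[O-])c([N+](=O)[O-])c2)s1)Nc1cc(Cl)cc(Cl)c1` gives > 20000 nM, which is also a limit and not a number. Compound 1 therefore has no exact place on the scale, and the two results together show only (the limit of > 20000 nM in this assay, at which 2 of the 2 values shown sit).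

Compound 3 `O=C(NCCNS(=O)(=O)c1sccc1-c1ccccc1Oc1ccc(O)c(O)c1)Nc1cc(C(F)(F)F)cc(C(F)(F)F)c1` is a close relative of compound 1: hydrogen in place of methyl on an aromatic carbon. In words, hydrogen takes the place of methyl on an aromatic carbon, meta to a 3,4-dihydroxyphenoxy group and para to a large group. For the measured compounds named here, no pair of measured compounds shows what this kind of change does in this assay, so any forecast is uncertain. The expectation starts from compound 1 at > 20000 nM, and no shift beyond the usual scatter is foreseen in either direction. The expected change, a number no higher from compound 1 to compound 3 (the limit leaves the size open), is accordingly small. Compound 3 is estimated at 20000 nM, with an expected range of 9000 nM to 40000 nM, and its result may well be a limit again.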

Compound 3, half-maximal inhibitory concentration: 8900 nM
Beside the measured number, compound 3's estimate is 2.2-fold (0.35 log units) above it, and the stated range ends above it.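

Hydrogen in place of methyl on the aromatic carbon, meta to a 3,4-dihydroxyphenoxy group and para to a large group, gives an at least 2.2-fold lower number from compound 1 to compound 3 (0.35 log units; beyond the scatter) in this assay. For the compounds shown here, this shows that the position is not silent in this assay: the loss of one methyl is enough to carry the result beyond the usual scatter of repeated measurements, which the earlier compounds could not show. The value of compound 1, > 20000 nM, is a limit and not a number, so the step has a minimum size but no exact size, and the other compounds offer little to set it against: the limit of > 20000 nM in this assay, at which 2 of the 3 values shown sit.

This single pair cannot show whether the methyl is special or whether any group on this carbon would keep the number high; an ethyl group, a chlorine atom or a methoxy group at the same place would begin to answer that. It also leaves open whether hydrogen in place of methyl would act the same way on a core carrying other groups, such as the dinitrophenoxy and dichlorophenyl groups of compound 2.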